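Two Inactive Triazole Amides and a Benzyl Variant

A few compounds are considered here, and "the series" means these few. Any claim that something is new, unique, unknown or untested is made for them only; others in the source may bear on it.

Compound 2 `Cc1ccc(-n2cc(CNC(=O)c3cccc4c3cnn4C(C)C)nn2)cc1` was tested in a functional assay on HepG2 cells (Homo sapiens) for inhibition, read by MTT assay, with a stated time of 72 h; a higher number here means a weaker inhibitor, a lower number a stronger inhibitor. In this assay compound 2 gives only a limit, > 40000 nM, not a number. For the measured compounds named here, the one other compound with a value, compound 1 `CC(C)n1ncc2c(C(=O)NCc3cn(-c4cccc(F)c4)nn3)cccc21`, differs from it only by 4-methylphenyl in place of 3-fluorophenyl on an aromatic nitrogen. In this assay compound 1 likewise gives only a limit, > 40000 nM. The step that the two limits leave unreadable from compound 1 to compound 2 therefore cannot be read, since the limit of > 40000 nM in this assay, at which 2 of the 2 values shown sit, is where both values sit.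

Compound 3 `CC(C)n1ncc2c(C(=O)NCc3cn(Cc4ccc(C#N)cc4)nn3)cccc21` has not yet been measured. Its change from compound 2 is 4-cyanobenzyl in place of 4-methylphenyl on an aromatic nitrogen. Going by the values given here, no measured step touches a benzyl group at this position, and the only measured step on this aromatic nitrogen is unreadable, so there is no step to lean on. With both known compounds at the limit, compound 3 is expected to stay near that limit too, and the step of a number no higher from compound 2 to compound 3 (the limit leaves the size open) is estimated to be none beyond the scatter. Compound 3 is accordingly estimated at 40000 nM, with a range from 15000 nM to 100000 nM, most likely reported as a limit again.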

Compound 3, half-maximal inhibitory concentration: > 40000 nM
Compound 3: no number, only a limit (the forecaster's own chance of this, stated with the estimate: 80%); the middle value sits exactly at the limit.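

In this assay compound 3 gives > 40000 nM, a limit and not a number. The steps among compound 1, compound 2 and compound 3 therefore cannot be read, and all three compounds share one limit: the limit of > 40000 nM in this assay, at which 3 of the 3 values shown sit.

The compounds shown leave open whether any group on this aromatic nitrogen can give a measurable value in this assay.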